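This account rests on a few compounds, and the source may have more. Where it says the series, first, only, none or still open, it means among the compounds named here.

Compound 1 `C=CC(=O)Nc1cccc(-c2nc3ccccc3s2)c1` was examined in an ADME assay on BJ cells (Homo sapiens) for inhibition, with a stated time of 72 h; a lower number here means that less compound is needed, a higher number that more compound is needed for the effect. Compound 1 stands only at a limit of the assay, giving > 25000 nM rather than a number. Compound 2 `O=C(O)/C=C/C(=O)Nc1cccc(-c2nc3ccccc3s2)c1` likewise returns only a limit, > 25000 nM. Compound 3 `CN(C)CCC(=O)Nc1cccc(-c2nc3ccccc3s2)c1` also returns only a limit, > 25000 nM. The steps a step that the two limits leave unreadable from compound 1 to compound 2, a step that the two limits leave unreadable from compound 1 to compound 3 and a step that the two limits leave unreadable from compound 2 to compound 3 cannot be sized because of the limit of > 25000 nM in this assay, at which 3 of the 3 values shown sit. Compound 4 `O=C(Nc1cccc(-c2nc3ccccc3s2)c1)c1ccnc(Cl)c1` differs from compound 1 by 2-chloropyridin-4-yl in place of vinyl on a carbonyl carbon. Within the data shown here, no measured step replaces the vinyl on the carbonyl carbon with an aromatic ring, so none bears directly on this change, and the three limits give no readable size to build on. A step that the limit leaves unreadable from compound 1 to compound 4 is expected, meaning no readable change. Compound 4 is estimated at 30000 nM, within 8000 nM to 100000 nM.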

Compound 4, half-maximal effective concentration: > 25000 nM
Compound 4 gave a limit, no number; the forecaster's own chance of this, stated with the estimate: 75%; the middle value is on the limit's open side.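

No step from compound 1, compound 2 or compound 3 to compound 4 can be read, because all four compounds give only a limit: the limit of > 25000 nM in this assay, at which 4 of the 4 values shown sit.

The compounds shown leave open whether any group on the carbonyl carbon would give a number rather than a limit.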